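The source may report more compounds than this note shows. Statements on the series, on what has been measured and on what is new or still open speak of the compounds shown alone.

In an in vitro ADME assay on microsomes from liver (Mus musculus) for metabolic stability, tested at 0.2 uM (on this read-out higher numbers stand for fast clearance and lower numbers for slow clearance), compound 1 (`Cc1c(COc2cccc(OCC3CCOCC3)c2)[nH]c2ccc(C(=O)O)cc2c1=O`) gives only a limit (< 50 mL/min/kg). Compound 2 (`Cc1c(COc2cccc(OCC3CCOCC3)c2)[nH]c2ccc(Cl)cc2c1=O`) also gives only a limit (> 1000 mL/min/kg), and it stands at the fast-clearance end of the two values. Compound 3 (`Cc1c(COc2cccc(OCC3CCOCC3)c2)[nH]c2ccc(-c3cccnc3)cc2c1=O`) carries pyridin-3-yl in place of chloro on an aromatic carbon. Within the data shown here, the one measured step at this place is large (an at least 20-fold higher number from compound 1 to compound 2 (1.30 log units; beyond the scatter)), but compound 3 has no carboxy, so that step bears only loosely and a smaller fall in this assay is expected. For compound 3 the expected step is (an at least 2.0-fold lower number from compound 2 to compound 3 (0.30 log units; that floor lies within the scatter)). Compound 3 is estimated at (500 mL/min/kg), within a range from (150 mL/min/kg) to (1500 mL/min/kg).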

Compound 3, clearance: > 1000 mL/min/kg
Compound 3: no number, only a limit; the forecaster's own chance of this, stated with the estimate: 35%; middle value at least 2.0-fold (0.30 log units) from the limit.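

In this assay, pyridin-3-yl in place of carboxy on this aromatic carbon gives an at least 20-fold higher number from compound 1 to compound 3 (1.30 log units; beyond the scatter), so a second group without carboxy now joins chloro at the fast-clearance end. The step from chloro to pyridin-3-yl cannot be read, since both values are limits: the limit of > 1000 mL/min/kg in this assay, at which 2 of the 3 values shown sit. Of the three groups at this place, only carboxy gives a value at the slow-clearance end: the limit of < 50 mL/min/kg in this assay, at which 1 of the 3 values shown sits.

The compounds shown leave open whether a carboxamide, a methyl ester or an amine at this carbon would stay with carboxy at the slow-clearance end. As far as these compounds go, how far compound 2 and compound 3 lie apart also stays open.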